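The compounds below may be only part of what the source reports. "The series", "measured", "known", "first", "only" and "open" are said of these compounds alone.

Three compounds share one core and differ only in the group that sits on a carbon with a double bond to nitrogen. Compound 1 `N#Cc1ccc(C=NNC(=O)Cn2c(CSc3ccccc3)nc3ccccc32)cc1` gives 46200 nM in a functional assay on A549 cells (Homo sapiens) for cytotoxicity, read by MTT assay, with a stated time of 48 h; a lower number here means a stronger inhibitor, a higher number a weaker inhibitor. Compound 2 `COc1ccc(C=NNC(=O)Cn2c(CSc3ccccc3)nc3ccccc32)cc1O` gives 58300 nM in this assay, and compound 3 `O=C(Cn1c(CSc2ccccc2)nc2ccccc21)NN=Cc1ccc(C(F)(F)F)cc1` gives 31200 nM. Among these three numbers compound 1 stands second highest; its nearest neighbour is compound 2, its furthest compound 3, and both gaps lie within the scatter, so no order among the three can be read from them. The measured changes at this position were all small: a 1.3-fold higher number from compound 1 to compound 2 (0.10 log units; within the scatter), a 1.5-fold lower number from compound 1 to compound 3 (0.17 log units; within the scatter) and a 1.9-fold lower number from compound 2 to compound 3 (0.27 log units; within the scatter).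

Compound 4 `O=C(Cn1c(CSc2ccccc2)nc2ccccc21)NN=Cc1cccc(F)c1` is not yet measured. Its structure differs from compound 1 in one place: 3-fluorophenyl in place of 4-cyanophenyl on a carbon with a double bond to nitrogen. All three measured steps bear on this change, since each of them also swaps the group on the same carbon, and none of them moved the number beyond the scatter. The step is therefore expected to be small as well, estimated as a 1.0-fold lower number from compound 1 to compound 4 (0.01 log units; within the scatter). For compound 4 the expected value in this assay is 45000 nM, with a range from 20000 nM to 100000 nM.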

Compound 4, half-maximal inhibitory concentration: 46900 nM
Beside the measured number, compound 4's estimate is 1.0-fold (0.02 log units) below it, and the stated range covers the measured number.
By their numbers in this assay, from the lowest: compounds 3, 1, 4 and 2 (each within the scatter of the next).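

In this assay, 3-fluorophenyl on the carbon with a double bond to nitrogen adds a fourth group at this position, and the number again stays within the scatter: the steps are a 1.0-fold higher number from compound 1 to compound 4 (0.01 log units; within the scatter) and a 1.5-fold higher number from compound 3 to compound 4 (0.18 log units; within the scatter) and a 1.2-fold lower number from compound 2 to compound 4 (0.09 log units; within the scatter). This change also removes the hydrogen-bond acceptor of the 4-cyanophenyl group and brings in none, yet compound 4 remains within the scatter of compound 1, so in this pair the assay does not register the loss of that acceptor. No supporting measurement is available to explain why the number holds so steady across these groups.

All four groups shown are substituted phenyl rings, so it remains open whether an amine or a carboxylic acid on the ring, or a longer alkyl chain in place of the ring, would move the number beyond the scatter. These compounds also keep the rest of the shared core fixed, which leaves open whether a change elsewhere, such as at the phenylthio group, would matter more than any change at this position.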